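Replacing an ether by a methylated amide on the core

The source may hold more compounds than are shown below. What is called first, only, known or untested is meant among the compounds shown, and "the series" means these compounds.

Compound 3 `Cc1nn(-c2ncnc3nc[nH]c23)c2c1C(OCc1ccc(F)cc1)CC(=O)N2` gives 1 nM in a functional assay on HEK293 cells for agonist activity at G-protein coupled receptor 39 (Homo sapiens), read by scintillation proximity assay and inositol phosphate accumulation, with a stated time of 75 min, in the presence of a further agent that is not named here (on this read-out higher numbers stand for an effect only at larger amounts of compound and lower numbers for an effect already at smaller amounts), the lowest number among the three measured compounds. Compound 1 `Cc1nn(-c2ncnc3nc[nH]c23)c2c1C(C(=O)Nc1ccccc1)CC(=O)N2` gives 10 nM in this assay, and compound 2 `Cc1cc(C)n(CCOC2CC(=O)Nc3c2c(C)nn3-c2ncnc3nc[nH]c23)n1` gives 16 nM. The two steps leading to compound 3 were a 10-fold lower number from compound 1 to compound 3 (1.00 log units; beyond the scatter) and a 16-fold lower number from compound 2 to compound 3 (1.20 log units; beyond the scatter), while between the other two there was a 1.6-fold higher number from compound 1 to compound 2 (0.20 log units; within the scatter).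

Compound 4 `Cc1nn(-c2ncnc3nc[nH]c23)c2c1C(C(=O)N(C)c1ccccc1)CC(=O)N2` differs from compound 3 by methyl(phenyl)carbamoyl in place of (4-fluorobenzyl)oxy on a saturated ring carbon. The measured step that bears on this is a 10-fold lower number from compound 1 to compound 3 (1.00 log units; beyond the scatter), since compound 1 carries phenylcarbamoyl at the same saturated ring carbon and compound 4 carries methyl(phenyl)carbamoyl, which differs from it only by an added methyl. Running that step backwards, compound 4 is expected to land near compound 1, with the added methyl leaving the outcome somewhat uncertain. The expected step is a 15-fold higher number from compound 3 to compound 4 (1.18 log units; beyond the scatter). Compound 4 is therefore estimated at 15 nM in this assay, with a likely range from 4 nM to 60 nM.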

Compound 4, half-maximal effective concentration: 32 nM
Compound 4: middle estimate off by 2.1-fold (0.33 log units), on the low side; the measured number falls inside the stated range.
By their numbers in this assay, from the lowest: compound 3; then compounds 1, 2 and 4 (each within the scatter of the next, the first and the last beyond it).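

In this assay, the methyl on the amide-type nitrogen is a small change with a readable effect: a 3.2-fold higher number from compound 1 to compound 4 (0.51 log units; beyond the scatter). The amide hydrogen therefore matters at this saturated ring carbon, yet the methylated amide remains well away from the best ether, a 32-fold higher number from compound 3 to compound 4 (1.51 log units; beyond the scatter), and the step of a 2.0-fold higher number from compound 2 to compound 4 (0.30 log units; within the scatter) stays within the scatter. Nothing measured here explains the effect of the methyl.

The compounds shown leave open whether ethyl on the same nitrogen would raise the number further, or whether a fluorine on the phenyl of the amide would lower it, as a 4-fluorophenyl is present in the ether of compound 3. They also leave open how a carboxylic acid or an amine would behave at this saturated ring carbon.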